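Sulfamide ureas on a diisopropylphenyl core: ring closure of the amine

The compounds below may be only part of what the source reports. "The series", "measured", "known", "first", "only" and "open" are said of these compounds alone.

Measured so far:
compound 1 `CC(C)NS(=O)(=O)NC(=O)Nc1c(C(C)C)cccc1C(C)C`, 18000 nM
compound 2 `C=CCN(CC=C)S(=O)(=O)NC(=O)Nc1c(C(C)C)cccc1C(C)C`, 2700 nM
compound 3 `CCCN(CCC)S(=O)(=O)NC(=O)Nc1c(C(C)C)cccc1C(C)C`, 1100 nM

In an assay on liver for inhibition of sterol O-acyltransferase 1 (Rattus norvegicus), using microsomes (a higher number here means a weaker inhibitor, a lower number a stronger inhibitor), compound 3 gives the lowest number of the three. The nearest is compound 2, with a step of a 2.5-fold lower number from compound 2 to compound 3 (0.39 log units; beyond the scatter), and the furthest is compound 1, with a step of a 16-fold lower number from compound 1 to compound 3 (1.21 log units; beyond the scatter). Compound 1 to compound 2 is a 6.7-fold lower number from compound 1 to compound 2 (0.82 log units; beyond the scatter).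

Compound 4 `CC(C)c1cccc(C(C)C)c1NC(=O)NS(=O)(=O)N1CCCCC1` has not been measured. It differs from compound 3 in one place: piperidin-1-yl in place of dipropylamino on a sulfonyl sulfur. All three measured steps alter the same amino group on the sulfonyl sulfur, so all three bear on this change. Both steps away from isopropylamino, to a group carrying two chains on the nitrogen, lower the number, the larger of them a 16-fold lower number from compound 1 to compound 3 (1.21 log units; beyond the scatter); the exchange of diallylamino for dipropylamino is the smaller step of a 2.5-fold lower number from compound 2 to compound 3 (0.39 log units; beyond the scatter). Piperidin-1-yl keeps two carbon chains on the nitrogen, as in compound 3, but with one heavy atom fewer and joined into a ring. The step from compound 3 to compound 4 is therefore expected to be a 1.4-fold higher number from compound 3 to compound 4 (0.13 log units; within the scatter), small and possibly within the scatter. Compound 4 is estimated at 1500 nM, between 600 nM and 4000 nM.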

Compound 4, half-maximal inhibitory concentration: 17000 nM
For compound 4 the middle estimate is 11-fold (1.05 log units) below the measured one; measured number outside the range, above it.
By their numbers in this assay, from the lowest: compound 3; then compound 2; then compounds 4 and 1 (each within the scatter of the next).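

In this assay, joining the two chains on the nitrogen into piperidin-1-yl gives up nearly all of the gain seen with the open dipropylamino group (a 15-fold higher number from compound 3 to compound 4 (1.19 log units; beyond the scatter)). The ring also gives a higher number than the open diallylamino group (a 6.3-fold higher number from compound 2 to compound 4 (0.80 log units; beyond the scatter)) and cannot be told apart from the isopropylamino group (a 1.1-fold lower number from compound 1 to compound 4 (0.02 log units; within the scatter)), so compound 4 goes against the reading from compounds 1, 2 and 3 that two carbon chains on the nitrogen are enough to lower the number. No measurement at hand accounts for this loss on ring closure.

Compound 4 differs from compound 3 both in the ring and in having one heavy atom fewer, and the compounds shown do not separate these two changes. They also leave open whether the loss is specific to piperidin-1-yl or extends to other rings on the sulfonyl sulfur, such as pyrrolidin-1-yl, azepan-1-yl or morpholin-4-yl, and whether longer open chains such as dibutylamino go lower than dipropylamino.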